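A few compounds are considered here, and "the series" means these few. Any claim that something is new, unique, unknown or untested is made for them only; others in the source may bear on it.

Compound 1 `COc1ccc(-c2nc3ccccn3c2/C=C/C(=O)c2cc(OC)c(OC)c(OC)c2)cc1` gives 7420 nM in a functional assay on EKVX cells (Homo sapiens) for inhibition, read by sulforhodamine B assay, with a stated time of 48 h; a lower number here means a stronger inhibitor of growth, a higher number a weaker inhibitor of growth. Compound 2 `COc1cc(C(=O)/C=C/c2c(-c3cccs3)nc3ccccn23)cc(OC)c1OC` gives 3120 nM. Compound 3 `COc1cc(C(=O)/C=C/c2c(-c3ccc(F)cc3)nc3ncccn23)cc(OC)c1OC` gives 2710 nM.

Compound 3 has the lowest of the three numbers, though its gap to compound 2 lies within the scatter; only compound 1 stands clearly higher. Compound 4 `COc1ccc(-c2nc3ncccn3c2/C=C/C(=O)c2cc(OC)c(OC)c(OC)c2)cc1` carries methoxy in place of fluoro on an aromatic carbon. Going by the values given here, no measured step covers this change directly. Among the compounds with values here, the nearest guide is a 2.4-fold lower number from compound 1 to compound 2 (0.38 log units; beyond the scatter), where removing 4-methoxyphenyl lowered the number, and compound 1, the only 4-methoxyphenyl compound measured, has the highest value. A modest rise in this assay is therefore expected for compound 4, estimated as a 1.8-fold higher number from compound 3 to compound 4 (0.27 log units; within the scatter). Compound 4 is expected to give 5000 nM, between 2500 nM and 10000 nM.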

Compound 4, concentration for 50% growth inhibition: 1610 nM
Beside the measured number, compound 4's estimate is 3.1-fold (0.49 log units) above it; measured number outside the range, below it.
By their numbers in this assay, from the lowest: compounds 4, 3 and 2 (each within the scatter of the next); then compound 1.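

In this assay the change from 4-fluorophenyl to 4-methoxyphenyl on this core reads as a 1.7-fold lower number from compound 3 to compound 4 (0.23 log units; within the scatter) and so stays inside the usual scatter. The 4-methoxyphenyl group therefore does not go with a high number everywhere: compound 1 gives 7420 nM on its core, while compound 4 gives 1610 nM on the core it shares with compound 3. Nothing shown explains this result. Still open, from the compounds shown here alone, is whether an amine or a longer chain such as ethoxy at this place would move the number beyond the scatter. Also open, going by these compounds, is how thiophen-2-yl behaves on the core of compound 3.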